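The source may hold more compounds than are shown below. What is called first, only, known or untested is meant among the compounds shown, and "the series" means these compounds.

Measured so far:
compound 1 `O=[N+]([O-])c1cccc(C2=NC(c3ccc(F)cc3)(c3ccc(F)cc3)CN2)c1` with 4.3 nM; compound 2 `Fc1ccc(C2(c3ccc(F)cc3)CNC(c3ccsc3)=N2)cc1` with 93 nM.

Compound 2 stands at the higher of the two numbers measured in an assay on LM cells for displacement of a labelled ligand from Neuropeptide Y receptor type 5 (Homo sapiens); a higher number here means a weaker inhibitor, a lower number a stronger inhibitor; its nearest neighbour is compound 1, and the step of a 22-fold higher number from compound 1 to compound 2 (1.34 log units; beyond the scatter) separates them. That single step is the only one that bears on the change now considered, since compound 3 `N#Cc1cc(C2=NC(c3ccc(F)cc3)(c3ccc(F)cc3)CN2)ccn1` differs from compound 2 in the same place: 2-cyanopyridin-4-yl in place of thiophen-3-yl on a carbon with a double bond to nitrogen. The step from compound 1 to compound 2 shows that swapping a six-membered aromatic ring carrying a substituent for the thiophen-3-yl group raised the number by a large margin, well beyond the scatter. Compound 3 reverses that direction, bringing back a six-membered aromatic ring, now a 2-cyanopyridin-4-yl group, so a return toward the number of compound 1 is expected, though the new group is not the 3-nitrophenyl of compound 1 and the size of the recovery is uncertain. The estimated step of a 12-fold lower number from compound 2 to compound 3 (1.07 log units; beyond the scatter) is therefore expected to be a large decrease in this assay. For compound 3 the expected value in this assay is 8 nM, within a range from 2.5 nM to 25 nM.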

Compound 3, half-maximal inhibitory concentration: 4.8 nM
Compound 3: the middle estimate sits 1.7-fold (0.22 log units) above what was measured; measured number inside the range.
By their numbers in this assay, from the lowest: compounds 1 and 3 (each within the scatter of the next); then compound 2.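

In this assay, the step of a 19-fold lower number from compound 2 to compound 3 (1.29 log units; beyond the scatter) shows that a low number at this carbon, between the two ring nitrogen atoms, does not depend on the 3-nitrophenyl group of compound 1. The step of a 1.1-fold higher number from compound 1 to compound 3 (0.05 log units; within the scatter) cannot separate 2-cyanopyridin-4-yl from 3-nitrophenyl, even though the two groups differ in their ring atoms and in their substituent, so among these three compounds both six-membered, substituted aromatic rings stand apart from thiophen-3-yl, and none goes against this. The data offered here give no independent measurement that would explain this difference.

The compounds shown leave open whether the difference from compound 2 follows the six-membered ring itself or its substituent: a plain phenyl ring, or a pyridin-4-yl ring without the nitrile, would separate the two. Also open, as far as these compounds go, is whether a thiophen-3-yl ring carrying a nitrile would join compound 1 and compound 3, and whether an amine or a methoxy group on the six-membered ring would do the same.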